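The source may hold more compounds than are shown below. What is called first, only, known or untested is meant among the compounds shown, and "the series" means these compounds.

In an ADME assay on HEK293 cells (Homo sapiens) for cytotoxicity, read by luminescence, with a stated time of 72 h (on this read-out higher numbers stand for an effect only at larger amounts of compound and lower numbers for an effect already at smaller amounts), compound 1 `CCOC(=O)c1c(-c2cccc(OCC(C)C)c2)[nH]c2cc(OC)ccc2c1=O` gives > 22000 nM, which is a limit and not a number. Compound 2 `CCOC(=O)c1c(-c2cccc(OCc3ccccc3)c2)[nH]c2cc(OC)ccc2c1=O` gives > 22000 nM, which is also a limit. The picture so far is therefore (the limit of > 22000 nM in this assay, at which 2 of the 2 values shown sit), and compound 2 has no exact value. Compound 3 `CCOC(=O)c1c(-c2cccc(Oc3ccccc3)c2)[nH]c2cc(OC)ccc2c1=O` has not yet been measured. It differs from compound 2 in one place: phenyl in place of benzyl on an oxygen on an aromatic ring. This is phenyl in place of benzyl on an oxygen on an aromatic ring, or benzyloxy to phenoxy. For the measured compounds named here, one measured step bears on this, a step that the two limits leave unreadable from compound 1 to compound 2, and its size cannot be read, so it gives no sign of a change in either direction. The expected step is a step that the limit leaves unreadable from compound 2 to compound 3, with none expected beyond the scatter in this assay. The estimate for compound 3 is 25000 nM, with an expected range from 10000 nM to 50000 nM.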

Compound 3, half-maximal effective concentration: > 22000 nM
Compound 3 ended at the assay's limit; the forecaster's own chance of this, stated with the estimate: 80%; the middle value does not contradict the limit.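

The steps among compound 1, compound 2 and compound 3 cannot be read, because each result is a limit and not a number: the limit of > 22000 nM in this assay, at which 3 of the 3 values shown sit.

The compounds shown leave open whether the isobutyl, benzyl and phenyl groups on that oxygen differ at all in this assay.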